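The source may report more compounds than this note shows. Statements on the series, on what has been measured and on what is new or still open speak of the compounds shown alone.

Compound 1, `CCOC(=O)c1csc2nc(CN3CCN(Cc4ccccc4)CC3)c(-c3ccc(C)cc3)n12`, was tested in a functional assay on MCF7 cells (Homo sapiens) for antiproliferative activity, read by MTT assay, with a stated time of 72 h (a higher number here means a weaker inhibitor, a lower number a stronger inhibitor), where compound 1 gives 29100 nM. Compound 2, `CCOC(=O)c1csc2nc(CN3CCN(Cc4ccccc4)CC3)c(-c3ccc(OC)cc3)n12`, carries methoxy in place of methyl on an aromatic carbon, and in this assay compound 2 gives 17100 nM. The step is a 1.7-fold lower number from compound 1 to compound 2 (0.23 log units; within the scatter), so the two numbers cannot be told apart here.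

Compound 3, `CC(=O)NNC(=O)c1csc2ncc(-c3ccc(C)cc3)n12`, belongs to a different core; the difference between the two cores is not broken down here. In this assay compound 3 gives 57300 nM. Its number and that of compound 1 lie within the scatter of each other, while its number stands higher than that of compound 2 by a margin beyond the scatter.

Compound 4, `COc1ccc(-c2cnc3scc(C(=O)NNC(C)=O)n23)cc1`, is not yet measured. It differs from compound 3 by methoxy in place of methyl on an aromatic carbon, the same change that turns compound 1 into compound 2, made at a place described in the same words: on an aromatic carbon of a six-membered aromatic ring of carbon only, para to a large group. Since that change produced a 1.7-fold lower number from compound 1 to compound 2 (0.23 log units; within the scatter), a step within the scatter, the expected step on the core of compound 3 is also a small one, estimated as a 1.6-fold lower number from compound 3 to compound 4 (0.21 log units; within the scatter). The number expected for compound 4 in this assay is 35000 nM, with an estimated range from 15000 nM to 85000 nM.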

Compound 4, half-maximal inhibitory concentration: 8360 nM
Beside the measured number, compound 4's estimate is 4.2-fold (0.62 log units) above it; measured number below the stated range.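

In this assay, methoxy in place of methyl on an aromatic carbon gives a 6.9-fold lower number from compound 3 to compound 4 (0.84 log units; beyond the scatter), so on this core the change separates the two compounds clearly, which it does not do on the core of compound 1. The size of the step therefore did not carry from one core to the other: the same change on two cores in this assay, a 1.7-fold lower number (0.23 log units; within the scatter) from compound 1 to compound 2 and a 6.9-fold lower number (0.84 log units; beyond the scatter) from compound 3 to compound 4, 4.0-fold (0.61 log units) apart, beyond the scatter of two such steps. This shows that, in these two pairs, a step measured on one core was a poor guide to its size on the other, but with one pair per core it does not show why, nor which of the several differences between the cores is responsible, and it sets no general rule for the series.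

The compounds shown leave open whether a chlorine, a fluorine, a hydroxyl or an ethoxy group at the same place on the aromatic ring would also give a larger step on the core of compound 3 than on the core of compound 1. They also leave open whether the larger step would survive if the acetyl hydrazide of compound 3 gave way to a carboxylic acid or an amine.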